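This account rests on a few compounds, and the source may have more. Where it says the series, first, only, none or still open, it means among the compounds named here.

Compound 1, `COc1ccccc1Cn1cc(CCCCC[C@@H]2SC[C@@H]3NC(=O)N[C@@H]32)nn1`, and compound 2, `COc1cccc(Cn2cc(CCCCC[C@@H]3SC[C@@H]4NC(=O)N[C@@H]43)nn2)c1`, share one core and differ only in the group attached to the saturated chain carbon bound to an aromatic nitrogen. In an assay on isolated protein for inhibition of biotin--protein ligase (Homo sapiens), read by scintillation counting, with a stated time of 10 min (a higher number here means a weaker inhibitor, a lower number a stronger inhibitor), compound 1 gives > 16000 nM, which is a limit of the assay rather than a measured number. In this assay compound 2 gives > 16000 nM, again a limit and not a number. The step that the two limits leave unreadable from compound 1 to compound 2 is therefore unreadable: moving the methoxy group from one ring position to another changed nothing that the assay could see. Compound 2 thus stands at the limit of > 16000 nM in this assay, at which 2 of the 2 values shown sit.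

Compound 3, `Cc1cccc(Cn2cc(CCCCC[C@@H]3SC[C@@H]4NC(=O)N[C@@H]43)nn2)c1`, differs from compound 2 by methyl in place of methoxy on an aromatic carbon. Within the data shown here, the only measured step was left unreadable by the two limits, so it offers no guidance on size or direction for this change. The expected step is accordingly a step that the limit leaves unreadable from compound 2 to compound 3, nothing beyond the scatter. Compound 3 is estimated to give 25000 nM, with a range from 10000 nM to 60000 nM, and most probably the assay will again report only a limit.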

Compound 3, inhibition constant: > 16000 nM
Compound 3 ended at the assay's limit; the forecaster's own chance of this, stated with the estimate: 80%; the middle value is on the limit's open side.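

In this assay compound 3 gives > 16000 nM, again a limit and not a number. The steps joining compound 3 to compound 1 and compound 2 therefore cannot be read, and all three stand at the same place: the limit of > 16000 nM in this assay, at which 3 of the 3 values shown sit.

The compounds shown leave open how strongly each one inhibits the enzyme, and whether any change to the group on the shared core would give a readable number.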